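Swapping Methoxy for Cyano on the Benzyl Arm

The source may report more compounds than this note shows. Statements on the series, on what has been measured and on what is new or still open speak of the compounds shown alone.

Compound 1 `CNC(=O)c1cc(C(=O)NC2CC2)cn(Cc2cccc(OC)c2)c1=O`: in a physicochemical assay for solubility (a higher number here means a more soluble compound, a lower number a less soluble compound), compound 1 gives 79 ug/mL.
Compound 2 `CNC(=O)c1cc(C(=O)NCCC2CCOCC2)cn(Cc2ccccc2)c1=O`: in this assay compound 2 gives >= 127 ug/mL, which is a limit of the assay rather than a number.
Compound 3 `CNC(=O)c1cc(C(=O)NC)c(=O)n(Cc2ccccc2)c1`: in this assay compound 3 gives >= 118 ug/mL, again a limit and not a number.

For the measured compounds named here, compound 1 is the only compound here with a full number in this assay; the other two values sit at limits, namely the limit of >= 118 ug/mL in this assay, at which 1 of the 3 values shown sits, and (the limit of >= 127 ug/mL in this assay, at which 1 of the 3 values shown sits). Going by the values given here, the one step between measured compounds, a step that the two limits leave unreadable from compound 2 to compound 3, has no readable size, as both of its ends are limits.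

Compound 4 `CNC(=O)c1cc(C(=O)NC2CC2)cn(Cc2cccc(C#N)c2)c1=O` differs from compound 1 by cyano in place of methoxy on an aromatic carbon. Among the compounds with values here, no measured step touches this kind of change, and the unreadable step gives no guide either, so there is no basis to expect movement beyond the usual scatter in either direction. Compound 4 is therefore expected to give about 70 ug/mL, with a range from 30 ug/mL to 160 ug/mL. The expected step of a 1.1-fold lower number from compound 1 to compound 4 (0.05 log units; within the scatter) is thus estimated to lie within the scatter.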

Compound 4, solubility: >= 148 ug/mL
Compound 4 was reported as a limit; the forecaster's own chance of this, stated with the estimate: 15%; at least 2.1-fold (0.32 log units) between middle value and limit.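

For the compounds shown here, the change from 3-methoxyphenyl to 3-cyanophenyl gives the first step in this set with a readable direction, an at least 1.8-fold higher number from compound 1 to compound 4 (0.27 log units; that floor lies within the scatter). In this assay, the value of compound 4 is a limit and not a number: the limit of >= 148 ug/mL in this assay, at which 1 of the 4 values shown sits.
At this aromatic carbon on the benzyl arm, then, the swap brought no drop in the read-out, but the size of any rise remains unread, and the part that is secure does not clear the scatter.

Steps with a limit at both ends cannot be read, so the compounds shown give no second measure of how far this read-out can move. On these data alone, how a carboxylic acid or a dimethylamino group at this same aromatic carbon would compare with methoxy and cyano remains open.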